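A few compounds are considered here, and "the series" means these few. Any claim that something is new, unique, unknown or untested is made for them only; others in the source may bear on it.

Measured compounds:
compound 1, `CCNc1cc(C)c2cc(NC(=O)c3ccc(Cl)c(Cl)c3)ccc2n1`, 28200 nM
compound 2, `CCN1CCN(c2cc(C)c3cc(NC(=O)c4cc5ccccc5[nH]4)ccc3n2)CC1`, 2550 nM

Both were tested in a functional assay on SK-BR-3 cells (Homo sapiens) for antiproliferative activity, read by MTT assay, with a stated time of 72 h; a higher number here means a weaker inhibitor, a lower number a stronger inhibitor. Compound 1 gives 28200 nM, the higher of the two numbers, so it is the weaker inhibitor of the pair; compound 2, which differs from it in several places at once, gives 2550 nM, and that gap lies beyond the usual scatter. The unmeasured compound 3, `CCN(CC)CCNc1cc(C)c2cc(NC(=O)c3ccc(Cl)c(Cl)c3)ccc2n1`, shares the core of compound 1 and changes one thing: diethylamino in place of hydrogen on a saturated chain carbon, two bonds along the chain from a nitrogen on an aromatic ring. For the measured compounds named here, with only two measured compounds and no single-change pair among them, there is no measured step to lean on. A moderate drop in the number, toward a stronger inhibitor, is expected, though a step within the scatter would not be surprising. For compound 3 the expected step is a 3.1-fold lower number from compound 1 to compound 3 (0.50 log units; beyond the scatter). In this assay compound 3 is estimated at 9000 nM, within a range from 2500 nM to 32000 nM.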

Compound 3, half-maximal inhibitory concentration: 3710 nM
Compound 3: middle estimate off by 2.4-fold (0.38 log units), on the high side; low and high end bracket the measured number.
By their numbers in this assay, from the lowest: compounds 2 and 3 (each within the scatter of the next); then compound 1.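

Until now no single change could be read in this assay. This pair supplies one: diethylamino in place of hydrogen on a saturated chain carbon, two bonds along the chain from a nitrogen on an aromatic ring, gives a 7.6-fold lower number from compound 1 to compound 3 (0.88 log units; beyond the scatter) and so a stronger inhibitor, showing that this position tolerates a group of 5 heavy atoms and that activity improves with it. No measurement shown here accounts for that improvement, so what lies behind it remains unknown.

Going by these compounds, it remains open whether the nitrogen at the end of the chain matters, which a plain pentyl chain or a hydroxyl or carboxylic acid at that end could test. Also open, on these data alone, is how dimethylamino, or a longer chain carrying the same diethylamino group, would compare with compound 3 on the same core.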